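Methyl-Triazole Swap on the Shared Core

This account rests on a few compounds, and the source may have more. Where it says the series, first, only, none or still open, it means among the compounds named here.

Within the data shown here, compound 1 `c1ccc(-c2nc[nH]n2)c(NCC2=NCCN2)c1` is the only compound here with a numbered result: in an in vitro functional assay on cells (Fibroblast) for agonist activity at Alpha-1D adrenergic receptor (Homo sapiens) (a higher number here means that more compound is needed for the effect, a lower number that less compound is needed), compound 1 gives 3.98 nM. Compound 2 `CCn1ccc(-c2ccccc2NCC2=NCCN2)n1` gives in this assay < 100000 nM, which is a limit of the assay rather than a number. Compound 3 `Cn1ncnc1-c1ccccc1NCC1=NCCN1` has not been measured; it differs from compound 1 by 1-methyl-1H-1,2,4-triazol-5-yl in place of 1H-1,2,4-triazol-3-yl on an aromatic carbon. Among the measured compounds shown here, no measured step covers this change, so the expected step rests on the change alone. A moderate weakening is expected, with an estimated step of a 7.5-fold higher number from compound 1 to compound 3 (0.88 log units; beyond the scatter). Compound 3 is therefore estimated at 30 nM in this assay, within a range from 3 nM to 300 nM.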

Compound 3, half-maximal effective concentration: 63.1 nM
Beside the measured number, compound 3's estimate is 2.1-fold (0.32 log units) below it; measured number inside the range.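

Setting 1-methyl-1H-1,2,4-triazol-5-yl in place of 1H-1,2,4-triazol-3-yl on the aromatic carbon brings a 16-fold higher number from compound 1 to compound 3 (1.20 log units; beyond the scatter) in this assay and shows that this position responds strongly to the swap. Compound 3 still gives a measured number, whereas compound 2 stands only at a limit of the assay. The entering group has 0 hydrogen-bond donors where the leaving group has 1, yet the added methyl comes with that loss, so the two cannot be told apart here.

From the compounds shown here alone, how a hydroxyethyl chain or an aminomethyl group in place of the methyl would read out remains open. No measurement shown accounts for the step.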